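Replacing Allyl with 2-Chlorobenzyl on the Shared Core

The compounds below may be only part of what the source reports. "The series", "measured", "known", "first", "only" and "open" are said of these compounds alone.

Compound 2 `C=CCNc1n[n+]([O-])c2ccccc2[n+]1[O-]` carries an allyl group on a nitrogen on an aromatic ring of the shared core. In a functional assay on K562 cells (Homo sapiens) for cytotoxicity, read by MTT assay, with a stated time of 48 h (on this read-out lower numbers stand for stronger inhibition and higher numbers for weaker inhibition), compound 2 gives 11200 nM, the highest of the three numbers at hand. Compound 1 `[O-][n+]1nc(NC2CCCCC2)[n+]([O-])c2ccccc21` carries cyclohexyl at the same nitrogen and in this assay gives 2600 nM, while compound 3 `[O-][n+]1nc(Nc2ccccc2)[n+]([O-])c2ccccc21` carries phenyl there and gives 2400 nM. The two steps that touch compound 2 both move the number: a 4.3-fold higher number from compound 1 to compound 2 (0.63 log units; beyond the scatter) and a 4.7-fold lower number from compound 2 to compound 3 (0.67 log units; beyond the scatter), so the open allyl chain stands apart from both ring-bearing substituents.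

Compound 4 `[O-][n+]1nc(NCc2ccccc2Cl)[n+]([O-])c2ccccc21` differs from compound 2 by 2-chlorophenyl in place of vinyl on a saturated chain carbon bound to a nitrogen on an aromatic ring. Again a six-membered ring enters where the allyl group stood, now one carbon away from the nitrogen. The steps from compound 2 to compound 3 and from compound 1 to compound 2 are the ones that bear on this change, and both were modest and beyond the scatter. A step of similar size and in the lowering direction is therefore expected, a 3.7-fold lower number from compound 2 to compound 4 (0.57 log units; beyond the scatter). Compound 4 is estimated at 3000 nM, within a range of 1200 nM to 8000 nM.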

Compound 4, half-maximal inhibitory concentration: 2200 nM
Estimate against measurement, compound 4: 1.4-fold (0.13 log units) above, within the range that was stated.
By their numbers in this assay, from the lowest: compounds 4, 3 and 1 (each within the scatter of the next); then compound 2.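

In this assay, the step of a 5.1-fold lower number from compound 2 to compound 4 (0.71 log units; beyond the scatter) shows that a six-membered aromatic ring need not stand directly on the nitrogen: here the ring sits on a saturated chain carbon and carries a chlorine, yet the number still moves well away from that of compound 2. Compound 4 lies within the scatter of compound 3, and compound 3 within that of compound 1, so at this position three ring-bearing groups form one level, with compound 2 alone apart and no compound shown going against this. No measurement at hand accounts for the shift.

A plain benzyl group would show what the chlorine adds to this step, while a hexyl chain would test whether an open chain can reach the same level. A morpholine ring or a carboxylic acid on the chain also remains an open case.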